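The source may report more compounds than this note shows. Statements on the series, on what has been measured and on what is new or still open speak of the compounds shown alone.

In a functional assay on the whole organism (trachea) for inhibition, with Cavia porcellus as the target (a lower number here means that less compound is needed, a higher number that more compound is needed for the effect), compound 1 `O=C(O)CC/C=C\C[C@@H]1CN(S(=O)(=O)c2cccc3ccccc23)C[C@@H]1c1ccccc1O` gives 0.0075 mg/kg, the lowest of the three numbers available. Compound 2 `O=C(O)CC/C=C\C[C@@H]1CN(Cc2ccccc2)C[C@@H]1c1ccccc1O` gives 0.17 mg/kg, and compound 3 `CCCCCCC(=O)N1C[C@@H](C/C=C\CCC(=O)O)[C@@H](c2ccccc2O)C1` gives 0.43 mg/kg. Compound 4 `O=C(O)CC/C=C\C[C@@H]1CN(S(=O)(=O)c2cccc3cnccc23)C[C@@H]1c1ccccc1O` keeps the core of compound 1 but carries isoquinolin-5-yl in place of naphthalen-1-yl on a sulfonyl sulfur. For the measured compounds named here, no measured step covers this exchange. The only one available, a 2.5-fold higher number from compound 2 to compound 3 (0.40 log units; beyond the scatter), is modest and concerns a group on an amine nitrogen in a ring, so it offers only a rough guide to size. A modest rise in this assay is therefore expected, although a change within the scatter remains possible. The expected change is a 2.7-fold higher number from compound 1 to compound 4 (0.43 log units; beyond the scatter). For compound 4 the estimated value is 0.02 mg/kg, with an expected range from 0.005 mg/kg to 0.08 mg/kg.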

Compound 4, dose for 50% inhibition: 0.011 mg/kg
Beside the measured number, compound 4's estimate is 1.8-fold (0.26 log units) above it; the measured number falls inside the stated range.
By their numbers in this assay, from the lowest: compounds 1 and 4 (each within the scatter of the next); then compound 2; then compound 3.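

Exchanging naphthalen-1-yl for isoquinolin-5-yl on a sulfonyl sulfur gives a 1.5-fold higher number from compound 1 to compound 4 (0.17 log units; within the scatter) in this assay. This is the only step shown at this place, and it shows that a ring nitrogen, counted as one hydrogen-bond acceptor, can enter this aromatic group while the number stays within the scatter. The shared core and the sulfonyl link remain unchanged in this step. From the compounds shown here alone, whether a single phenyl ring, or an isoquinolin-5-yl group carrying an amine, would keep the number within the scatter on that sulfonyl sulfur remains open. No evidence on the cause of this result is at hand.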